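A few compounds are considered here, and "the series" means these few. Any claim that something is new, unique, unknown or untested is made for them only; others in the source may bear on it.

Compound 1 `Cc1nc(NC(=O)NC2CCCCC2)c(C)c(C(OC(C)(C)C)C(=O)O)c1-c1ccc(Cl)cc1` was tested in an ADME assay on MT4 cells (Homo sapiens) for cytotoxicity, read by MTT assay (a higher number here means that more compound is tolerated, a lower number that less compound is tolerated), where compound 1 gives 16000 nM. Within the data shown here, compound 2 `Cc1ccc(-c2c(C)nc(NS(=O)(=O)c3cccc4ccccc34)c(C)c2C(OC(C)(C)C)C(=O)O)cc1C` is the only other measured compound in this set; in this assay compound 2 gives 16000 nM. The two numbers are level at the digits shown, so compound 1 and compound 2 sit together within the usual scatter, and neither can be called the better tolerated. Among the measured compounds shown here, the two structures differ in several places at once, so no single-point step between them is counted.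

Compound 3 `Cc1nc(NC(=O)NC2CCCCC2)c(C)c(C(OC(C)(C)C)C(=O)O)c1-c1ccc(C(F)(F)F)cc1` has not yet been measured. It differs from compound 1 in one place: trifluoromethyl in place of chloro on an aromatic carbon, so a 4-chlorophenyl becomes a 4-(trifluoromethyl)phenyl. For the measured compounds named here, no measured pair in the set shows this exchange, so there is no step to lean on. Going by the values given here, with only two compounds, both at the same level, the expectation is a step from compound 1 to compound 3 of a 1.1-fold lower number from compound 1 to compound 3 (0.06 log units; within the scatter), small, within the scatter, with no clear direction. Compound 3 is therefore estimated at 14000 nM, with a range from 6000 nM to 32000 nM.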

Compound 3, half-maximal cytotoxic concentration: 9800 nM
For compound 3 the middle estimate is 1.4-fold (0.15 log units) above the measured one; the range from low to high includes it.
By their numbers in this assay, from the lowest: compounds 3, 1 and 2 (each within the scatter of the next).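

In this assay, among these compounds, placing trifluoromethyl where compound 1 has chloro gives a 1.6-fold lower number from compound 1 to compound 3 (0.21 log units; within the scatter) and provides the first single-place comparison in this set. At this position on the aromatic ring, a group of four heavy atoms can therefore replace one of a single heavy atom without a change that can be separated from the usual scatter of the measurement. Nothing available here explains this result, and with a step this small there is little to explain.

Among the compounds shown here, this single exchange covers only two groups at one position, so it leaves open whether the position would respond differently to an amino group or a longer alkyl chain, which differ more from chloro than trifluoromethyl does in what they bring to the ring. It also leaves open whether swapping chloro for trifluoromethyl would give a similar small step if the cyclohexyl urea elsewhere on the shared core were replaced by another side group.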